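Removing the methyl from the methoxy group of compound 2

The source may report more compounds than this note shows. Statements on the series, on what has been measured and on what is new or still open speak of the compounds shown alone.

Of the compounds shown here, three sharing one core have been tested in a functional assay on SNB-75 cells (Homo sapiens) for inhibition, read by sulforhodamine B assay, with a stated time of 48 h; on this read-out higher numbers stand for weaker inhibition of growth and lower numbers for stronger inhibition of growth. Compound 1 `O=C(Nc1cccc(-n2cc(-c3ccncc3)c(-c3ccc(Cl)c(O)c3)n2)c1)Nc1cccc(C(F)(F)F)c1` gives 3650 nM. Compound 2 `COc1cc(-c2nn(-c3cccc(NC(=O)Nc4cc(C(F)(F)F)cc(C(F)(F)F)c4)c3)cc2-c2ccncc2)ccc1Cl` gives 858 nM, and compound 3 `COc1cc(-c2nn(-c3cccc(NC(=O)Nc4cccc(C(F)(F)F)c4)c3)cc2-c2ccncc2)ccc1Cl` gives 1160 nM. Compound 2 thus has the lowest of the three numbers; compound 3 is its nearest neighbour and the two lie within the scatter of each other, while compound 1 sits furthest away, beyond the scatter.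

The new compound, compound 4 `O=C(Nc1cccc(-n2cc(-c3ccncc3)c(-c3ccc(Cl)c(O)c3)n2)c1)Nc1cc(C(F)(F)F)cc(C(F)(F)F)c1`, differs from compound 2 in one place: hydrogen in place of methyl on an oxygen on an aromatic ring. Of the measured steps, only one touches this position. From compound 1 to compound 3 the methyl was added to the oxygen, and the number fell: a 3.1-fold lower number from compound 1 to compound 3 (0.50 log units; beyond the scatter). The step from compound 2 to compound 4 runs the same change in reverse, so the number is expected to rise by about that amount, which means a step of a 3.1-fold higher number from compound 2 to compound 4 (0.50 log units; beyond the scatter) in this assay.

On that basis compound 4 is estimated to give 2700 nM in this assay, with a plausible range from 1300 nM to 5500 nM.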

Compound 4, concentration for 50% growth inhibition: 877 nM
Estimate against measurement, compound 4: 3.1-fold (0.49 log units) above; the whole stated range lies above it.
By their numbers in this assay, from the lowest: compounds 2, 4 and 3 (each within the scatter of the next); then compound 1.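

In this assay, the change from methoxy to hydroxy makes no difference beyond the scatter when the extra trifluoromethyl is present (a 1.0-fold higher number from compound 2 to compound 4 (0.01 log units; within the scatter)), so what this change does depends on the rest of the molecule and cannot be read from the position alone: the same change on two cores in this assay, a 3.1-fold lower number (0.50 log units; beyond the scatter) from compound 1 to compound 3 and a 1.0-fold lower number (0.01 log units; within the scatter) from compound 4 to compound 2, 3.1-fold (0.49 log units) apart, beyond the scatter of two such steps. The extra trifluoromethyl shows the same dependence in reverse, with a clear step between the two hydroxy compounds (a 4.2-fold lower number from compound 1 to compound 4 (0.62 log units; beyond the scatter)) but none beyond the scatter between the two methoxy compounds: the same change on two cores in this assay, a 1.4-fold higher number (0.13 log units; within the scatter) from compound 2 to compound 3 and a 4.2-fold higher number (0.62 log units; beyond the scatter) from compound 4 to compound 1, 3.1-fold (0.49 log units) apart, beyond the scatter of two such steps. Among these four compounds, then, only compound 1, which has hydroxy and lacks the extra trifluoromethyl, stands apart from the rest, so the two changes do not simply add up.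

The compounds shown carry only hydroxy or methoxy at this place, so how an amine or a longer chain such as ethoxy would behave there stays open. Four compounds in a single cell line also cannot tell why the two changes depend on each other, or whether that dependence holds in other cells.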